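This account rests on a few compounds, and the source may have more. Where it says the series, first, only, none or still open, it means among the compounds named here.

Measured compounds in this study:

Compound 1, `O=C1O/C(=C\Cn2cc(-c3ccc(Br)cc3)nn2)C(OCc2ccccc2)=C1OCc1ccccc1`. In a functional assay on A549 cells (Homo sapiens) for antiproliferative activity, read by MTT assay, with a stated time of 72 h (on this read-out higher numbers stand for weaker inhibition and lower numbers for stronger inhibition), compound 1 gives > 100000 nM, which is a limit of the assay and not a number.
Compound 2, `COc1ccc(-c2cn(C/C=C3\OC(=O)C(OCc4ccccc4)=C3OCc3ccccc3)nn2)cc1`. In this assay compound 2 gives > 100000 nM, again a limit rather than a number.
Compound 3, `CCCCCCCCCCc1cn(C[C@H](O)[C@H]2OC(=O)C(OCc3ccccc3)=C2OCc2ccccc2)nn1`. In this assay compound 3 gives 6750 nM.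

Within the data shown here, compound 3 thus stands as the only compound with a read number; the other two values shown sit at the limit of > 100000 nM in this assay, at which 2 of the 3 values shown sit. Among the measured compounds shown here, the one step between measured compounds, from compound 1 to compound 2, is a step that the two limits leave unreadable from compound 1 to compound 2, and so teaches nothing about size.

The unmeasured compound 4 is `O=C1O[C@H]([C@@H](O)Cn2cc(-c3cc(F)cc(F)c3)nn2)C(OCc2ccccc2)=C1OCc1ccccc1`. It differs from compound 3 by 3,5-difluorophenyl in place of decyl on an aromatic carbon. For the measured compounds named here, no measured step changes that group on the five-membered ring, so none bears directly on this change. Going by the values given here, what the data show is only that the two compounds carrying an aryl group at that position, compound 1 and compound 2, sit at the limit, while compound 3 with the decyl chain gives a number; compound 4 also differs from those two in the linker, so the comparison is loose. The account therefore expects a move toward weaker inhibition, with a step from compound 3 to compound 4 of about a 5.9-fold higher number from compound 3 to compound 4 (0.77 log units; beyond the scatter), and estimates for compound 4 in this assay a value of 40000 nM, between 8000 nM and 150000 nM, with a real chance that only a limit is reported.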

Compound 4, half-maximal inhibitory concentration: 41200 nM
Compound 4: the middle estimate sits 1.0-fold (0.01 log units) below what was measured; measured number inside the range.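

In this assay, 3,5-difluorophenyl in place of decyl on an aromatic carbon of the five-membered aromatic ring with 3 nitrogen gives a 6.1-fold higher number from compound 3 to compound 4 (0.79 log units; beyond the scatter), the first readable size for a change at this position. The step is modest, and it shows that a six-membered aromatic ring of carbon only at this place can still leave a read number, so an aryl group here does not by itself bring a compound to the limit of the assay. The earlier compounds could not show this, as their only step could not be read and a limit is not a number: the limit of > 100000 nM in this assay, at which 2 of the 4 values shown sit.

Among these compounds, the single step does not tell whether the lower number of compound 3 goes with the length of the decyl chain or with the absence of a ring at this carbon, a question that a hexyl chain or an unsubstituted phenyl at the same place would help to separate. Also open is how an amine or a carboxylic acid at this carbon would read, and what the hydroxyl-bearing linker contributes, as no pair shown changes that linker alone.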